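From Nitrophenyl to Bromothiophene on the Carbonyl

The source may report more compounds than this note shows. Statements on the series, on what has been measured and on what is new or still open speak of the compounds shown alone.

Two compounds share one core and differ in a single group. Compound 1 `COc1ccc(C(=O)/C=C/c2nc3ccccc3cc2-c2ccc(OC)cc2)cc1` gives 6420 nM in a functional assay on NCI-H1299 cells (Homo sapiens) for antiproliferative activity, read by XTT assay, with a stated time of 72 h; a lower number here means a stronger inhibitor, a higher number a weaker inhibitor. Compound 2 `COc1ccc(-c2cc3ccccc3nc2/C=C/C(=O)c2ccc([N+](=O)[O-])cc2)cc1` gives 770 nM in this assay, the lowest of the two numbers, and the measured step is an 8.3-fold lower number from compound 1 to compound 2 (0.92 log units; beyond the scatter). Compound 3 `COc1ccc(-c2cc3ccccc3nc2/C=C/C(=O)c2ccc(Br)s2)cc1` carries 5-bromothiophen-2-yl in place of 4-nitrophenyl on a carbonyl carbon. For the measured compounds named here, no measured step exchanges one ring for another at this carbonyl carbon, so the nitro-for-methoxy step is only a loose guide. Compound 3 is expected to show a modest rise, a 2.6-fold higher number from compound 2 to compound 3 (0.41 log units; beyond the scatter). Compound 3 is estimated at 2000 nM, between 600 nM and 7000 nM.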

Compound 3, half-maximal inhibitory concentration: 710 nM
Estimate against measurement, compound 3: 2.8-fold (0.45 log units) above, and the stated range covers the measured number.
By their numbers in this assay, from the lowest: compounds 3 and 2 (each within the scatter of the next); then compound 1.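

In this assay, exchanging 4-nitrophenyl for 5-bromothiophen-2-yl on the carbonyl carbon gives a 1.1-fold lower number from compound 2 to compound 3 (0.04 log units; within the scatter), so a five-membered ring with bromine serves here as well as the six-membered nitro-bearing ring. Set against the 4-methoxyphenyl group, the same thiophene gives a 9.0-fold lower number from compound 1 to compound 3 (0.96 log units; beyond the scatter), so the lower number is not tied to the nitro group alone. Nothing available explains why these two different groups read alike. Open, from the compounds shown here alone, is how an amine or a carboxylic acid would fare on the ring at this carbonyl carbon.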